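Working notes on compound 3 and its methoxy analogue

The compounds below may be only part of what the source reports. "The series", "measured", "known", "first", "only" and "open" are said of these compounds alone.

The series shares the core seen in compound 1 `COc1cc(NC(C)CCCNC(=O)NCCCO)c2ncccc2c1` and compound 2 `COc1cc(NC(C)CCCNC(=O)NC2CCCC2)c2ncccc2c1`. In an ADME assay on L6 cells (Rattus norvegicus) for cytotoxicity, read by resazurin assay, with a stated time of 70 h (a lower number here means a stronger inhibitor, a higher number a weaker inhibitor), the entry for compound 1 reads "not determined" (no result reported), and for compound 2 it reads "not determined" (no result reported); neither gives a number, so neither can anchor a comparison. Going by the values given here, compound 3 `COc1cc(NC(C)CCCNC(=O)NNC(=O)/C=C/c2ccccc2)c2ncccc2c1` is the one member with a figure: in this assay compound 3 gives 13900 nM. On the numbers shown it therefore stands alone, with nothing weaker or stronger beside it, and no step between measured compounds can be drawn.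

Compound 4 `COc1ccc(/C=C/C(=O)NNC(=O)NCCCC(C)Nc2cc(OC)cc3cccnc23)cc1` differs from compound 3 in one place: methoxy in place of hydrogen on an aromatic carbon, para to a large group. Cut one bond further out, the change reads phenyl to 4-methoxyphenyl. Among the compounds with values here, with no measured step to lean on, the expectation is that this change moves the reading of compound 4 little if at all, so the step from compound 3 to compound 4 is estimated at a 1.1-fold lower number from compound 3 to compound 4 (0.03 log units; within the scatter), within the usual scatter and in no firm direction. Compound 4 is therefore expected to give about 13000 nM in this assay, with a range from 5000 nM to 35000 nM.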

Compound 4, half-maximal inhibitory concentration: 3600 nM
Compound 4: the middle estimate sits 3.6-fold (0.56 log units) above what was measured, outside the stated range (below it).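

With compound 3 and compound 4 the series has its first measured step: in this assay the step reads a 3.9-fold lower number from compound 3 to compound 4 (0.59 log units; beyond the scatter) and shows that methoxy in place of hydrogen on an aromatic carbon, para to a large group, does change the reading, in the direction of a stronger inhibitor. The earlier entries could not show this, since compound 3 alone carried a number, so this place on the ring now counts as one that responds to substitution in this cytotoxicity read-out. The finding rests on a single pair and a step graded as modest, so it holds for phenyl to 4-methoxyphenyl and sets no rule for the series, and nothing measured here bears on why the reading moves.

Still open, going by these compounds, is whether the step belongs to methoxy itself or would recur with another group at the same place, such as hydroxyl, an amine or a carboxylic acid. Equally open, on these data alone, is whether a longer chain on that oxygen would extend the step or reverse it.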